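A Benzoxazole Swap in a Permeability Series

The compounds below may be only part of what the source reports. "The series", "measured", "known", "first", "only" and "open" are said of these compounds alone.

Three related acids give a thin starting point. In an ADME assay on LLC-PK1 cells (Sus scrofa) for permeability, with a stated time of 3 h, tested at 1 uM (on this read-out lower numbers stand for lower permeability and higher numbers for higher permeability), compound 1 `O=C(O)CNC(=O)c1c(O)c2ccc(Cl)cc2n(Cc2ccc(C(F)(F)F)cc2)c1=O` gives 16 10^-6 cm/s. Compound 2 `O=C(O)CNC(=O)c1c(O)c2c(n(Cc3ccc(F)cc3F)c1=O)COC2` gives no number, only a limit of the assay: < 2.2 10^-6 cm/s. For compound 3 `O=C(O)CNC(=O)c1c(O)c2c(n(Cc3ncc(C(F)(F)F)cn3)c1=O)COC2` the entry reads "not determined" (no result reported), so it adds nothing to compare.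

Compound 4 `O=C(O)CNC(=O)c1c(O)c2c(n(Cc3nc4ccccc4o3)c1=O)COC2` differs from compound 2 in one place, with 1,3-benzoxazol-2-yl in place of 2,4-difluorophenyl on a saturated chain carbon bound to an aromatic nitrogen. Within the data shown here, no measured pair shows what such a swap does. The expected step that the limit leaves unreadable from compound 2 to compound 4 therefore stays within the usual scatter, with no direction favoured. For compound 4 the estimate is 2 10^-6 cm/s, with an expected range from 1 10^-6 cm/s to 6 10^-6 cm/s.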

Compound 4, apparent permeability: < 1.9 10^-6 cm/s
Compound 4: a limit, no number; the forecaster's own chance of this, stated with the estimate: 60%; at least 1.0-fold (0.02 log units) between middle value and limit.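

Among these compounds, compound 2 and compound 4 each carry only a limit of the assay, not a number, and no step between them can be read. The compounds shown leave open whether 1,3-benzoxazol-2-yl and 2,4-difluorophenyl differ at all in this assay.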